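From 4-Fluorophenyl to 2,4-Difluorophenyl

The compounds below may be only part of what the source reports. "The series", "measured", "known", "first", "only" and "open" are said of these compounds alone.

Compound 3, `C[C@H](Nc1cc(F)c(S(=O)(=O)Nc2nccs2)cc1Cl)c1ccc(F)cc1`, is the starting point. In an assay on HEK293 cells for inhibition of SCN8A/SCN1B (Homo sapiens), read by patch clamp, with a stated time of 20 min (on this read-out higher numbers stand for weaker inhibition and lower numbers for stronger inhibition), compound 3 gives 230 nM. Among the three compounds measured this is the second highest number: compound 2, `C[C@H](Nc1cc(F)c(S(=O)(=O)Nc2nccs2)cc1Cl)c1ccccc1`, gives 20 nM, and compound 1, `CCC(c1ccccc1)N(C)c1ccc(S(=O)(=O)Nc2nccs2)cc1Cl`, gives 1410 nM. Compound 2 and compound 3 differ in one place, and the step of a 12-fold higher number from compound 2 to compound 3 (1.06 log units; beyond the scatter) shows that the fluoro of the 4-fluorophenyl group cost a good deal of inhibition.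

Compound 4, `C[C@H](Nc1cc(F)c(S(=O)(=O)Nc2nccs2)cc1Cl)c1ccc(F)cc1F`, takes the same route one step further. The change is fluoro in place of hydrogen on an aromatic carbon; the new group enters on an aromatic carbon of the six-membered aromatic ring of carbon only, ortho to a large group and meta to the fluoro already present, so the 4-fluorophenyl becomes 2,4-difluorophenyl.

For the measured compounds named here, only one measured step bears on this: the step from compound 2 to compound 3, where a fluoro entered the same ring and the number rose sharply. Going by the values given here, the new fluoro enters elsewhere on that ring, so the outcome need not repeat, but the single precedent points toward weaker inhibition. Compound 4 is therefore expected to give 450 nM, within 150 nM to 1400 nM, and the expected step is a 2.0-fold higher number from compound 3 to compound 4 (0.29 log units; within the scatter).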

Compound 4, half-maximal inhibitory concentration: 40 nM
For compound 4 the middle estimate is 11-fold (1.05 log units) above the measured one; the whole stated range lies above it.
By their numbers in this assay, from the lowest: compounds 2 and 4 (each within the scatter of the next); then compound 3; then compound 1.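

In this assay the second fluoro does not repeat the earlier loss: the same kind of change gave a 12-fold higher number from compound 2 to compound 3 (1.06 log units; beyond the scatter) on this ring, while here it gives a 5.8-fold lower number from compound 3 to compound 4 (0.76 log units; beyond the scatter) in the new place. Fluoro in place of hydrogen on this ring can therefore move the number in either direction, so the place where the atom enters matters as much as the atom itself. Set against the plain phenyl group, the 2,4-difluorophenyl group gives a 2.0-fold higher number from compound 2 to compound 4 (0.30 log units; within the scatter) and the two numbers cannot be told apart on this read-out, so the large loss seen with the 4-fluorophenyl group does not remain once the new fluoro is present, and nothing shown here says why the added fluoro has this outcome.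

The compounds shown leave open whether a chloro, methyl or methoxy group on the same aromatic carbon would give a number like that of the fluoro. They also leave open whether the 2,4-difluorophenyl group would behave in the same way on the core of compound 1, which differs from the others in more than one place.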